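Oxazole ketone series: 2-fluorophenyl in place of methoxy

The source may hold more compounds than are shown below. What is called first, only, known or untested is meant among the compounds shown, and "the series" means these compounds.

Compound 3 `COc1cnc(C(=O)CCCCCCc2ccccc2)o1` shares its core with compound 1 `CC(=O)c1cnc(C(=O)CCCCCCc2ccccc2)o1` and compound 2 `CN(C)C(=O)c1cnc(C(=O)CCCCCCc2ccccc2)o1`. In an assay on HEK-293T cells for inhibition of diacylglycerol lipase-alpha (Homo sapiens), read by colorimetric assay (on this read-out lower numbers stand for stronger inhibition and higher numbers for weaker inhibition), compound 3 gives > 10000 nM, which is a limit of the assay. Compound 1 gives > 10000 nM, also a limit. Compound 2 gives > 10000 nM, again a limit. All three values sit at the limit of > 10000 nM in this assay, at which 3 of the 3 values shown sit, so the steps a step that the two limits leave unreadable from compound 1 to compound 2, a step that the two limits leave unreadable from compound 1 to compound 3 and a step that the two limits leave unreadable from compound 2 to compound 3 cannot be sized. Compound 4 `O=C(CCCCCCc1ccccc1)c1ncc(-c2ccccc2F)o1` arises from compound 3 by 2-fluorophenyl in place of methoxy on an aromatic carbon. Among the compounds with values here, no measured step exchanges a methoxy for an aryl group, so the measured data give no size for this change. The step is therefore estimated as an at least 4.0-fold lower number from compound 3 to compound 4 (0.60 log units; beyond the scatter), an expected gain with wide uncertainty. Compound 4 is expected at 2500 nM, within a range from 300 nM to 10000 nM.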

Compound 4, half-maximal inhibitory concentration: > 10000 nM
Compound 4 was reported as a limit (the forecaster's own chance of this, stated with the estimate: 40%); middle value at least 4.0-fold (0.60 log units) away from the limit.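

In this assay compound 4 gives > 10000 nM, a limit, so its steps from compound 1, compound 2 and compound 3 cannot be read: the limit of > 10000 nM in this assay, at which 4 of the 4 values shown sit.

The compounds shown leave open whether any group in this place on the shared core gives a value inside the measurable range.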